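Amide side-chain swap on two cores: working notes

The source may hold more compounds than are shown below. What is called first, only, known or untested is meant among the compounds shown, and "the series" means these compounds.

The measure throughout is a functional assay on PC-3 cells (Homo sapiens) for antiproliferative activity, read by MTT assay, with a stated time of 72 h; a higher number here means a weaker inhibitor, a lower number a stronger inhibitor. Compound 1 `CCn1c(C(=O)N[C@H](C(=O)O)C(C)C)ccc1C(CC)(CC)c1ccc(C#CC(O)(CC)CC)c(C)c1` gives 5000 nM in this assay, and compound 2 `CCn1c(C(=O)NCCC(=O)O)ccc1C(CC)(CC)c1ccc(C#CC(O)(CC)CC)c(C)c1` gives 5130 nM. The two share a core and differ only at the amide nitrogen, (1-carboxy-2-methylpropyl in place of 2-carboxyethyl on an amide-type nitrogen); the step of a 1.0-fold lower number from compound 2 to compound 1 (0.01 log units; within the scatter) is within the scatter, so the side-chain swap on this core leaves the read-out unchanged.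

Compound 3 `CCn1cc(C(CC)(CC)c2ccc(C#CC(O)(CC)CC)c(C)c2)cc1C(=O)NCCC(=O)O` carries the 2-carboxyethyl amide on a different core. For compound 3 this assay reports only a limit, > 50000 nM. This is the case noted as the limit of > 50000 nM in this assay, at which 1 of the 3 values shown sits. Compound 3 and compound 2 are built from the same atoms joined differently; the difference between the two cores is not broken down here.

Compound 4 `CCn1cc(C(CC)(CC)c2ccc(C#CC(O)(CC)CC)c(C)c2)cc1C(=O)N[C@H](C(=O)O)C(C)C` is the not yet measured partner of compound 3, made by the same change that turns compound 2 into compound 1: 1-carboxy-2-methylpropyl in place of 2-carboxyethyl on an amide-type nitrogen. The place of the change reads the same in both pairs, so it is the same change, not merely the same kind. Since compound 3 stands at a limit, the expected step from compound 3 to compound 4 is a step that the limit leaves unreadable from compound 3 to compound 4, resting on the null step a 1.0-fold lower number from compound 2 to compound 1 (0.01 log units; within the scatter) between compound 2 and compound 1. On that basis compound 4 is estimated at 60000 nM in this assay, with a range from 20000 nM to 200000 nM, and it is expected that this assay will most likely again report only a limit for compound 4.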

Compound 4, half-maximal inhibitory concentration: 3750 nM
The estimate for compound 4 lay 16-fold (1.20 log units) above the measured number; measured number outside the range, below it.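

Moving 1-carboxy-2-methylpropyl in place of 2-carboxyethyl on the amide-type nitrogen from the core of compound 1 to the core of compound 3 does not bring the same outcome, and the second core shows an at least 13-fold lower number from compound 3 to compound 4 (1.12 log units; beyond the scatter). In this assay the two pairs do not agree: the same change on two cores in this assay, a 1.0-fold lower number (0.01 log units; within the scatter) from compound 2 to compound 1 and an at least 13-fold lower number (1.12 log units; beyond the scatter) from compound 3 to compound 4, at least 12-fold (1.11 log units) apart, beyond the scatter of two such steps

Compound 3 is held only at a limit, so the full size of that step stays unread, and these two pairs show neither why the cores part nor how the change would behave on any further core: the limit of > 50000 nM in this assay, at which 1 of the 4 values shown sits.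

The compounds shown leave open whether the step on the core of compound 3 follows the branching of the chain, its defined stereocentre or simply its larger size. A carboxymethyl group, a longer unbranched chain ending in a carboxylic acid, or the opposite stereocentre of 1-carboxy-2-methylpropyl, each set on both cores, would separate these readings.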